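Azido in place of diethylamino: an expected rise

The source may hold more compounds than are shown below. What is called first, only, known or untested is meant among the compounds shown, and "the series" means these compounds.

Compound 1 `CCN(CC)C/C1=C/C[C@](C)(CCC=C(C)C)/C=C/[C@@H](OC(=O)C=C(C)C)[C@](C)(O)/C=C/C1=O` gives 570 nM as its value
Compound 2 `CC(C)=CCC[C@]1(C)/C=C/[C@@H](OC(=O)C=C(C)C)[C@](C)(O)/C=C/C(=O)/C(C[Si](c2ccccc2)(c2ccccc2)C(C)(C)C)=C\C1` gives 38000 nM as its value
Compound 3 `CC(C)=CCC[C@]1(C)/C=C/[C@@H](OC(=O)C=C(C)C)[C@](C)(O)CCC(=O)/C(CO)=C\C1` gives > 40000 nM as a limit and not a number

In a functional assay on SMMC-7721 cells (Homo sapiens) for antiproliferative activity, read by MTT assay, with a stated time of 48 h (on this read-out lower numbers stand for stronger inhibition and higher numbers for weaker inhibition), compound 1 has the lower of the two actual numbers, and the gap up to compound 2 lies beyond the scatter. For compound 3 there is only the limit of > 40000 nM in this assay, at which 1 of the 3 values shown sits, and no number.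

Compound 4 `CC(C)=CCC[C@]1(C)/C=C/[C@@H](OC(=O)C=C(C)C)[C@](C)(O)/C=C/C(=O)/C(CN=[N+]=[N-])=C\C1` has yet to be measured. Its structural change from compound 1 is azido in place of diethylamino on a saturated chain carbon bound to a double-bonded ring carbon, counted as azido in place of diethylamino on a saturated chain carbon bound to a double-bonded ring carbon in full. Compound 2 also has no diethylamino group and gives 38000 nM in this assay so a clear rise is expected for compound 4. The expected change is a step to a higher number, beyond the scatter, namely an 11-fold higher number from compound 1 to compound 4 (1.02 log units; beyond the scatter) on this estimate. Compound 4 is estimated at 6000 nM with an expected range from 1000 nM to 35000 nM on this reasoning.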

Compound 4, half-maximal inhibitory concentration: 3080 nM
Compound 4: middle estimate off by 1.9-fold (0.29 log units), on the high side, within the range that was stated.
By their numbers in this assay, from the lowest: compound 1; then compound 4; then compound 2. At a limit, above all of these: compound 3.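

In this assay, this position now has a direct comparison for a small replacement: azido in place of diethylamino, on a saturated chain carbon bound to a double-bonded ring carbon, gives a 5.4-fold higher number from compound 1 to compound 4 (0.73 log units; beyond the scatter). Removing the diethylamino group therefore weakens the result without abolishing it, as compound 4 gives 3080 nM, while compound 2, which carries the large silyl group at this place, gives 38000 nM. Compound 3 has only a limit and not a number, and it differs from compound 4 in more than one place, so it says nothing about this step: the limit of > 40000 nM in this assay, at which 1 of the 4 values shown sits.

The compounds shown do not tell why the step has this size. They also leave open how a primary amine, a morpholine or a carboxylic acid at this position would compare.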